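Methyl for Hydrogen on Compound 3's Aromatic Ring

This account rests on a few compounds, and the source may have more. Where it says the series, first, only, none or still open, it means among the compounds named here.

Of the compounds shown here, three have been measured in an assay on PBMC cells for antagonist activity at Toll-like receptor 9 (Homo sapiens), read by AlphaLISA, with stated times of 30 min and 20 h; on this read-out higher numbers stand for weaker inhibition and lower numbers for stronger inhibition. Compound 1 `Cn1cc(-c2ccc3nc(N4CCN(C5CCC5)CC4)ncc3c2)ccc1=O` gives 2200 nM. Compound 2 `Cc1cc(-c2ccc(=O)n(C)c2)cc2cnc(N3CCN(C(C)C)CC3)nc12` reaches only a limit of the assay, > 10000 nM. Compound 3 `Cc1cc(-c2ccc(=O)n(C)c2)cc2cn(C3CCNCC3)nc12` gives 2000 nM, the lowest of the two numbers, although its gap to compound 1 lies within the scatter, so the two cannot be ordered. Compound 4 `Cc1cc(-c2cc(C)c3nn(C4CCNCC4)cc3c2)cn(C)c1=O` has not yet been measured in this assay. It differs from compound 3 by methyl in place of hydrogen on an aromatic carbon, two atoms from the ring nitrogen and meta to a large group. Among the measured compounds shown here, no measured pair shows such a step, so only a modest shift, in either direction, is expected. Compound 4 is estimated at 1800 nM, within 600 nM to 5500 nM. The expected step, a 1.1-fold lower number from compound 3 to compound 4 (0.05 log units; within the scatter), should remain within the scatter.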

Compound 4, half-maximal inhibitory concentration: 200 nM
For compound 4 the middle estimate is 9.0-fold (0.95 log units) above the measured one; measured number outside the range, below it.
By their numbers in this assay, from the lowest: compound 4; then compounds 3 and 1 (each within the scatter of the next). At a limit, above all of these: compound 2.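

In this assay the methyl on an aromatic carbon, two atoms from the ring nitrogen and meta to a large group, brings a change beyond the scatter (a 10-fold lower number from compound 3 to compound 4 (1.00 log units; beyond the scatter)). Among the compounds shown here, this is the first step between compounds differing in one place, and it shows that this position responds to even one added carbon. Nothing at hand accounts for the size of this step.

As far as these compounds go, whether an ethyl chain, a methoxy group or an amine at this carbon would give a lower or a higher number stays open. So does whether the same methyl would act alike on the core of compound 1.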